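A few compounds are considered here, and "the series" means these few. Any claim that something is new, unique, unknown or untested is made for them only; others in the source may bear on it.

Compound 1 `COc1cccc([C@@H](CO)O[C@H]2CCCN(Cc3ccc(C(=O)O)cc3C)[C@H]2c2ccccc2)c1` and compound 2 `Cc1cc(C(=O)O)ccc1CN1CCC[C@H](O[C@H](CO)c2ccnc(Cl)c2)[C@@H]1c1ccccc1` share one core and differ only in the group on the saturated chain carbon bound to an oxygen. In an assay on isolated protein for activation of cGMP-dependent protein kinase 1 (Homo sapiens), read by ADP-Glo, with stated times of 30 min and 2 h (a higher number here means that more compound is needed for the effect, a lower number that less compound is needed), compound 1 gives only a limit, > 200000 nM. In this assay compound 2 likewise gives only a limit, > 200000 nM. The step that the two limits leave unreadable from compound 1 to compound 2 therefore has no readable size. Both known values sit on (the limit of > 200000 nM in this assay, at which 2 of the 2 values shown sit). Compound 3 `Cc1cc(C(=O)O)ccc1CN1CCC[C@H](O[C@H](CO)c2cccc(Cl)c2)[C@@H]1c1ccccc1` has not been measured in this assay; it differs from compound 2 by 3-chlorophenyl in place of 2-chloropyridin-4-yl on a saturated chain carbon bound to an oxygen on a saturated carbon and a saturated chain carbon. For the measured compounds named here, compound 2 stands at the limit of this assay, and the single measured step gives no direction and no size to carry over. For compound 3 the step expected is a number no higher from compound 2 to compound 3 (the limit leaves the size open), landing again at the limit. Compound 3 is estimated at 200000 nM, within a range of 60000 nM to 600000 nM.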

Compound 3, half-maximal effective concentration: 93000 nM
For compound 3 the middle estimate is 2.2-fold (0.33 log units) above the measured one; the measured number falls inside the stated range.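

In this assay the group on the saturated chain carbon bound to an oxygen now gives a first readable result: 3-chlorophenyl in place of 2-chloropyridin-4-yl gives an at least 2.1-fold lower number from compound 2 to compound 3 (0.33 log units; beyond the scatter). Chloro in place of methoxy on an aromatic carbon gives an at least 2.1-fold lower number from compound 1 to compound 3 (0.33 log units; beyond the scatter). From the compounds shown here alone, both readable steps end at compound 3 and point the same way, whereas the step between compound 1 and compound 2 cannot be read; with those two compounds held at a limit, the full size of each step stays open.

Going by these compounds, whether the chloro matters on the carbon-only ring remains open, and a plain phenyl would test this. Also open, on these data alone, is whether trifluoromethyl or an amine at that place would carry the number lower than in compound 3.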